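Growing the Side Group Next to the Piperidine Nitrogen

A few compounds are considered here, and "the series" means these few. Any claim that something is new, unique, unknown or untested is made for them only; others in the source may bear on it.

Measured compounds:
compound 1 `COc1ccc(CCCC(C)(C)C)c(N2CCC(COc3cccc(C(CC(=O)O)C4CC4)c3)CC2)c1`: 11 nM
compound 2 `COc1ccc(F)c(N2CCC(COc3cccc(C(CC(=O)O)C4CC4)c3)CC2)c1`: 670 nM
compound 3 `COc1ccc(C)c(N2CCC(COc3cccc(C(CC(=O)O)C4CC4)c3)CC2)c1`: 270 nM

Three compounds share one core and differ only in a single group on an aromatic carbon. In a functional assay on cells for agonist activity at Free fatty acid receptor 1 (Homo sapiens), read by FLIPR and calcium flux, with a stated time of 60 min (on this read-out higher numbers stand for an effect only at larger amounts of compound and lower numbers for an effect already at smaller amounts), compound 1 gives 11 nM, compound 2 gives 670 nM, and compound 3 gives 270 nM. Compound 3 therefore stands second highest of the three numbers: a 2.5-fold lower number from compound 2 to compound 3 (0.39 log units; beyond the scatter), whereas a 25-fold higher number from compound 1 to compound 3 (1.39 log units; beyond the scatter).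

Compound 4 `COc1ccc(C(C)C)c(N2CCC(COc3cccc(C(CC(=O)O)C4CC4)c3)CC2)c1` has not yet been measured. It differs from compound 3 by isopropyl in place of methyl on an aromatic carbon. Among the compounds with values here, two measured steps bear on this change: a 25-fold higher number from compound 1 to compound 3 (1.39 log units; beyond the scatter) and a 61-fold higher number from compound 1 to compound 2 (1.78 log units; beyond the scatter). In both, the 4,4-dimethylpentyl chain of compound 1 gave way to a smaller group and the number rose strongly. Isopropyl is neither the methyl of compound 3 nor the long chain of compound 1 but lies between them, so compound 4 is expected to give a lower number than compound 3 without reaching compound 1. The expected step is therefore a 3.9-fold lower number from compound 3 to compound 4 (0.59 log units; beyond the scatter). For compound 4 the estimate is 70 nM, with a range from 25 nM to 250 nM.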

Compound 4, half-maximal effective concentration: 120 nM
Estimate against measurement, compound 4: 1.7-fold (0.23 log units) below; the range from low to high includes it.
By their numbers in this assay, from the lowest: compound 1; then compound 4; then compound 3; then compound 2.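

Isopropyl in place of methyl brings a further gain at this position, ortho to a large group, with a 2.3-fold lower number from compound 3 to compound 4 (0.35 log units; beyond the scatter) in a single modest step, and the gain is larger against fluoro, with a 5.6-fold lower number from compound 2 to compound 4 (0.75 log units; beyond the scatter) as that comparison. Branching at the aromatic carbon is therefore enough to lower the number, yet most of the effect of the long chain remains out of reach, as an 11-fold higher number from compound 1 to compound 4 (1.04 log units; beyond the scatter) shows. Among the three carbon groups shown, the number falls as the group grows from methyl through isopropyl to 4,4-dimethylpentyl, a pattern resting on compound 3, compound 4 and compound 1 alone.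

On these data alone, whether tert-butyl, an unbranched propyl chain or a chain longer than 4,4-dimethylpentyl would continue this trend stays open, as does the effect of an amine here. The compounds shown also come with no measurement that accounts for these differences.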